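Replacing one 2-hydroxyphenyl on the shared core

A few compounds are considered here, and "the series" means these few. Any claim that something is new, unique, unknown or untested is made for them only; others in the source may bear on it.

Measured so far:
compound 1, `Oc1ccc(-c2cc(-c3ccccc3O)cc(-c3cccc(O)c3)n2)cc1`, a functional assay on T47D cells (Homo sapiens) for cytotoxicity, read by CCK-8 assay, with a stated time of 4 days; a higher number here means a weaker inhibitor, a lower number a stronger inhibitor: 650 nM
compound 2, `Oc1ccc(-c2cc(-c3ccc(O)cc3)nc(-c3ccc(O)cc3)c2)cc1`, this assay: 4270 nM
compound 3, `Oc1ccc(-c2cc(-c3ccccc3O)cc(-c3ccccc3O)n2)cc1`, this assay: 960 nM

Compound 3 stands second highest of the three numbers; its nearest neighbour is compound 1, a 1.5-fold higher number from compound 1 to compound 3 (0.17 log units; within the scatter), and its furthest is compound 2, whose number lies well beyond the scatter above that of compound 3.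

Compound 4, `Oc1ccc(-c2cc(-c3ccccc3O)cc(-c3ccc(O)cc3)n2)cc1`, differs from compound 3 in one place: 4-hydroxyphenyl in place of 2-hydroxyphenyl on an aromatic carbon. Within the data shown here, no measured step covers exactly this exchange. The step from compound 1 to compound 3 swaps a 3-hydroxyphenyl for a 2-hydroxyphenyl at the same kind of position and stays within the scatter. Compound 2, which carries 4-hydroxyphenyl at every position, shows the highest number of the set, and compound 4 lies structurally between compound 3 and compound 2. For compound 4 a step upward in this assay is therefore expected, roughly half way toward compound 2, as a 2.0-fold higher number from compound 3 to compound 4 (0.30 log units; within the scatter). The estimate for compound 4 in this assay is 1900 nM, with a range from 800 nM to 4500 nM.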

Compound 4, half-maximal inhibitory concentration: 5350 nM
For compound 4 the middle estimate is 2.8-fold (0.45 log units) below the measured one, and the stated range ends below it.
By their numbers in this assay, from the lowest: compounds 1 and 3 (each within the scatter of the next); then compounds 2 and 4 (each within the scatter of the next).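

At this place, next to the ring nitrogen, the choice among the hydroxyphenyl groups matters in this assay: 4-hydroxyphenyl in place of 2-hydroxyphenyl gives a 5.6-fold higher number from compound 3 to compound 4 (0.75 log units; beyond the scatter) and 4-hydroxyphenyl in place of 3-hydroxyphenyl gives an 8.2-fold higher number from compound 1 to compound 4 (0.92 log units; beyond the scatter) while the exchange between the other two groups gave only a 1.5-fold higher number from compound 1 to compound 3 (0.17 log units; within the scatter) at this place. With 4-hydroxyphenyl here, putting 2-hydroxyphenyl in place of 4-hydroxyphenyl at another place on the shared core gives a 1.3-fold higher number from compound 2 to compound 4 (0.10 log units; within the scatter) and so shows no separation of the two compounds. Nothing available bears on the reason for these steps.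

Open, going by these compounds, is whether an aminophenyl or a carboxyphenyl group at this place would keep the number near that of compound 3 or move it toward that of compound 4. Also open, on these data alone, is how a methoxyphenyl group would read here.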